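Compound 3: a side-chain replacement on the shared core

This account rests on a few compounds, and the source may have more. Where it says the series, first, only, none or still open, it means among the compounds named here.

In a functional assay on SGC-7901 cells (Homo sapiens) for cytotoxicity, read by MTT assay, with a stated time of 38 h (a higher number here means a weaker inhibitor, a lower number a stronger inhibitor), compound 1 `COc1cc(OC)c2c(=O)c(OCC(=O)N/N=C/c3ccc(C)cc3)c(-c3cc(OC)c(OC)c(OC)c3)oc2c1` gives 10100 nM and compound 2 `COc1cc(OC)c2c(=O)c(OCC(=O)N/N=C/c3ccc[nH]3)c(-c3cc(OC)c(OC)c(OC)c3)oc2c1` gives 8730 nM so the two sit within the scatter of each other. Compound 3 `COc1cc(OC)c2c(=O)c(OCCCCN3CCN(C)CC3)c(-c3cc(OC)c(OC)c(OC)c3)oc2c1` brings in 3-(4-methylpiperazin-1-yl)propyl, the change being a group of 10 heavy atoms (8 carbon, 2 nitrogen; one six-membered non-aromatic ring with 2 hetero atoms) in place of a group of 10 heavy atoms (6 carbon, 3 nitrogen, 1 oxygen; one five-membered aromatic ring with 1 hetero atom), on a saturated chain carbon bound to an oxygen on an aromatic ring in one replacement. For the measured compounds named here, the only measured step, a 1.2-fold lower number from compound 1 to compound 2 (0.06 log units; within the scatter) and thus within the scatter, swaps 4-methylphenyl for 1H-pyrrol-2-yl and does not cover this replacement. It offers no direction, so no step beyond the scatter is expected in this assay and the uncertainty stays wide. The expected change is a 1.2-fold lower number from compound 2 to compound 3 (0.10 log units; within the scatter) on this estimate. For compound 3 the estimate is 7000 nM with 2000 nM to 25000 nM as the expected range.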

Compound 3, half-maximal inhibitory concentration: 6950 nM
Compound 3: middle estimate off by 1.0-fold (0.00 log units), on the high side; the range from low to high includes it.
By their numbers in this assay, from the lowest: compounds 3, 2 and 1 (each within the scatter of the next).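

With 3-(4-methylpiperazin-1-yl)propyl on the saturated chain carbon bound to an oxygen on an aromatic ring, the steps are a 1.3-fold lower number from compound 2 to compound 3 (0.10 log units; within the scatter) and a 1.5-fold lower number from compound 1 to compound 3 (0.16 log units; within the scatter) in this assay and both stay within the scatter. The position therefore accepts a six-membered non-aromatic ring with 2 hetero atoms and 0 hydrogen-bond donors in place of either earlier group, with no step beyond the scatter. Nothing at hand accounts for this result.

Still open, on these data alone, is whether a morpholine or a primary amine at the end of this chain, or a longer chain, would move the number beyond the scatter.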